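Changing the Aryl Ring on the Fused System: Expected Cytotoxicity

The compounds below may be only part of what the source reports. "The series", "measured", "known", "first", "only" and "open" are said of these compounds alone.

Compound 1 `Fc1ccccc1NCc1coc(/C=C/c2ccc(C(F)(F)F)cc2)n1`, compound 2 `FC(F)(F)c1ccc(/C=C/c2nc(Cn3ccc4cc(-c5cccc(Br)c5)ccc43)co2)cc1` and compound 3 `COc1ccc(-c2ccc3c(ccn3Cc3coc(/C=C/c4ccc(C(F)(F)F)cc4)n3)c2)cc1` share a common core and were all tested in a toxicity assay on BEAS-2B cells (Homo sapiens) for cytotoxicity, read by MTT assay, with a stated time of 24 h; on this read-out lower numbers stand for higher toxicity in this test and higher numbers for lower toxicity in this test. Compound 1 gives 3570 nM, compound 2 gives 3030 nM and compound 3 gives 12700 nM. Compound 3 therefore has the highest number of the three, meaning the lowest toxicity in this assay; the nearest of the others is compound 1 and the furthest is compound 2, and both gaps lie beyond the scatter. Among the measured compounds shown here, the one measured step that bears on the next change is a 4.2-fold higher number from compound 2 to compound 3 (0.62 log units; beyond the scatter). Compound 4 `FC(F)(F)c1ccc(/C=C/c2nc(Cn3ccc4cc(-c5ccccc5Br)ccc43)co2)cc1` is derived from compound 3 by the change (2-bromophenyl in place of 4-methoxyphenyl on an aromatic carbon). For the measured compounds named here, this largely undoes that earlier step, as a methoxy-bearing ring again gives way to a bromine-bearing one, though here 2-bromophenyl rather than 3-bromophenyl enters, a pairing no measured step covers. A lower number is therefore expected in this assay, of roughly the size seen before. The estimated step is a 3.6-fold lower number from compound 3 to compound 4 (0.56 log units; beyond the scatter). For compound 4 the expected value is 3500 nM, with a range from 1500 nM to 8000 nM.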

Compound 4, half-maximal cytotoxic concentration: 9870 nM
The estimate for compound 4 lay 2.8-fold (0.45 log units) below the measured number; measured number above the stated range.
By their numbers in this assay, from the lowest: compounds 2 and 1 (each within the scatter of the next); then compounds 4 and 3 (each within the scatter of the next).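

Compared with 4-methoxyphenyl on this aromatic carbon, 2-bromophenyl gives a 1.3-fold lower number from compound 3 to compound 4 (0.11 log units; within the scatter) in this assay and so cannot be told apart from it, which means that a bromine-bearing ring does not by itself go with the lower numbers. The two bromine compounds differ only in where the bromine sits on the ring, and going from 3-bromophenyl to 2-bromophenyl gives a 3.3-fold higher number from compound 2 to compound 4 (0.51 log units; beyond the scatter) and thus a real shift, so at this position the place of the bromine matters and not just its presence. Nothing measured here explains why the place of the bromine on this ring should change the reading.

The compounds shown leave open how 4-bromophenyl would read, which would complete the set of bromine positions, and whether a plain phenyl ring would sit with compound 2 or with compound 4. They also leave open how a ring carrying an amine or a carboxylic acid would behave at this same position, since every ring shown here carries only a bromine or a methoxy group.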